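The source may report more compounds than this note shows. Statements on the series, on what has been measured and on what is new or still open speak of the compounds shown alone.

In an ADME assay on A549 cells (Homo sapiens) for cytotoxicity, with a stated time of 72 h (on this read-out lower numbers stand for stronger inhibition and higher numbers for weaker inhibition), compound 1 `COc1cc(NC(C)CCCN2C(=O)[C@@H](C)N(C(=O)CN)C2(C)C)c2ncccc2c1` gives > 100000 nM, which is a limit of the assay and not a number. Going by the values given here, compound 2 `COc1cc(NC(C)CCCN2C(=O)CN(C(=O)[C@@H](C)N)C2(C)C)c2ncccc2c1` gives 7800 nM, the only true number so far and therefore the single anchor on this scale. The next compound, compound 3 `COc1cc(NC(C)CCCN2C(=O)CN(C(=O)[C@H](N)C(C)C)C2(C)C)c2ncccc2c1`, differs from compound 2 at one place: isopropyl in place of methyl on a saturated chain carbon bound to an amine nitrogen and a carbonyl carbon, with isopropyl in place of methyl on a saturated chain carbon bound to an amine nitrogen and a carbonyl carbon. Among the compounds with values here, no measured pair shows this kind of change, so there is no earlier step to use as a guide. The estimate therefore leans on compound 2 at 7800 nM and stays close to it. A small step is expected, a 1.4-fold lower number from compound 2 to compound 3 (0.15 log units; within the scatter), leaning slightly towards lower numbers and not clearly beyond the usual scatter. For compound 3 the expected value is 5500 nM, with an estimated range of 2000 nM to 16000 nM.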

Compound 3, half-maximal inhibitory concentration in the A549 assay: 5500 nM
The estimate for compound 3 equals the measured number at the digits printed; low and high end bracket the measured number.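

In the A549 assay, the swap of methyl for isopropyl on this saturated chain carbon, bound to an amine nitrogen and a carbonyl carbon, gives a 1.4-fold lower number from compound 2 to compound 3 (0.15 log units; within the scatter), so the larger group leaves compound 2 and compound 3 indistinguishable on this read-out. Going by these compounds alone, this is the first pair differing in one place, and so the first direct reading of any change at this carbon. In a physicochemical assay for solubility (on this read-out lower numbers stand for lower solubility and higher numbers for higher solubility), compound 2 gives 120000 ug/mL and compound 3 gives 46500 ug/mL. In the physicochemical assay, the same swap does go beyond the usual scatter: the measured solubility of compound 2, 120000 ug/mL, and of compound 3, 46500 ug/mL, a 2.6-fold lower number (0.41 log units; beyond the scatter)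

The compounds shown hold only methyl and isopropyl at this carbon, leaving open how a longer chain, a phenyl ring or a carboxylic acid there would read in the A549 assay or the physicochemical assay. Within the data shown here, in the A549 assay, compound 1 gives > 100000 nM, which is a limit and not a number, so it sets the size of no step.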